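This account rests on a few compounds, and the source may have more. Where it says the series, first, only, none or still open, it means among the compounds named here.

For the measured compounds named here, in an assay on CHO cells, read by calcium flux (on this read-out lower numbers stand for stronger inhibition and higher numbers for weaker inhibition), compound 2 `O=C(Nc1ccc(C(F)(F)F)nc1)c1csc(Cc2c(Cl)cccc2Cl)n1` gives 110 nM, the only value in this set that is a plain number. Compound 1 `COc1ccc(NC(=O)c2csc(Cc3c(Cl)cccc3Cl)n2)cc1` reaches only a limit of the assay, > 4000 nM. Compound 3 `COc1ccc(NC(=O)c2csc(Cc3c(Cl)cccc3Cl)n2)cn1` differs from compound 2 in one place: methoxy in place of trifluoromethyl on an aromatic carbon. Going by the values given here, no measured pair shows this change directly. Compound 1 carries the same methoxy group and sits at the limit of > 4000 nM in this assay, at which 1 of the 2 values shown sits. On that basis the step is expected to weaken inhibition, estimated as a 14-fold higher number from compound 2 to compound 3 (1.13 log units; beyond the scatter). Compound 3 is expected to give about 1500 nM, somewhere between 300 nM and 6000 nM, with a fair chance of only a limit.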

Compound 3, half-maximal inhibitory concentration: > 4000 nM
Compound 3: no number, only a limit; the forecaster's own chance of this, stated with the estimate: 35%; at least 2.6-fold (0.42 log units) between middle value and limit.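

In this assay, for the compounds shown here, methoxy in place of trifluoromethyl on this aromatic carbon, next to the ring nitrogen, gives an at least 36-fold higher number from compound 2 to compound 3 (1.56 log units; beyond the scatter), the first direct evidence that this single change on the shared core costs much inhibition. Both methoxy compounds, compound 1 and compound 3, end at a limit of the assay rather than at a number: the limit of > 4000 nM in this assay, at which 2 of the 3 values shown sit. The step between those two compounds therefore cannot be read.

From the compounds shown here alone, whether a ring nitrogen matters when trifluoromethyl is kept stays open. Going by these compounds, it also stays open whether a nitrile, a chlorine or an amine on this carbon would retain inhibition.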